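The source may hold more compounds than are shown below. What is called first, only, known or untested is meant among the compounds shown, and "the series" means these compounds.

Working notes on the series. Compound 1 `O=C(/C=C/c1ccc2c(c1)B(O)OC2)c1ccc(O)cc1` sits at a limit in an ADME assay on L929 cells (Mus musculus) for cytotoxicity, read by resazurin assay, with a stated time of 72 h (on this read-out lower numbers stand for stronger inhibition and higher numbers for weaker inhibition), reported only as > 10 ug/mL. Compound 3 `COc1cc(C(=O)/C=C/c2ccc3c(c2)B(O)OC3)cc(OC)c1OC` is likewise reported only as a limit in this assay, > 10 ug/mL. Compound 2 `COc1cccc(C(=O)/C=C/c2ccccc2)c1` lacks the shared core of compound 1; in this assay compound 2 gives 5.7 ug/mL. Compound 1 therefore stands at the limit of > 10 ug/mL in this assay, at which 2 of the 3 values shown sit, and no numeric value separates it from the others at that limit. Compound 4 `O=C(/C=C/c1ccc2c(c1)B(O)OC2)c1ccccc1O` differs from compound 1 by 2-hydroxyphenyl in place of 4-hydroxyphenyl on a carbonyl carbon. Going by the values given here, no measured pair carries this change, so the expectation in this assay is for no step beyond the scatter and for compound 4 to remain at the limit. Compound 4 is estimated at 12 ug/mL, within 5 ug/mL to 30 ug/mL. The estimated step that the limit leaves unreadable from compound 1 to compound 4 is expected to be within the scatter.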

Compound 4, half-maximal inhibitory concentration: > 10 ug/mL
Compound 4 gave a limit, no number (the forecaster's own chance of this, stated with the estimate: 70%); the middle value is on the limit's open side.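

Compound 1 and compound 4 are both reported only as limits in this assay, so no step between them can be read: the limit of > 10 ug/mL in this assay, at which 3 of the 4 values shown sit.

The compounds shown leave open whether 2-hydroxyphenyl in place of 4-hydroxyphenyl on a carbonyl carbon changes the result in this assay at all.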